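Swapping Chloro for Sulfanyl on a Purine Core

A few compounds are considered here, and "the series" means these few. Any claim that something is new, unique, unknown or untested is made for them only; others in the source may bear on it.

Compound 1 `CC(=O)OC(C)n1cnc2c(Cl)nc(I)nc21` gives 6420 nM in a functional assay on HT-29 cells (Homo sapiens) for inhibition; a lower number here means a stronger inhibitor, a higher number a weaker inhibitor.
Compound 2 `Nc1nc(I)nc2c1ncn2OCCO` reports only a limit, > 500000 nM, in this assay.
Compound 3 `CC(=O)OC(C)n1cnc2c(Cl)nc(F)nc21` gives 75900 nM in this assay.

Among the two measured numbers, compound 3 stands highest; its nearest neighbour is compound 1, and the change a 12-fold higher number from compound 1 to compound 3 (1.07 log units; beyond the scatter) is the one step where the two structures differ in a single place. The limit of compound 2 is a boundary of the measurement, not a number, and it is the one such entry here (the limit of > 500000 nM in this assay, at which 1 of the 3 values shown sits).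

Compound 4 `CC(=O)OC(C)n1cnc2c(S)nc(F)nc21` has not yet been measured. It differs from compound 3 as follows: sulfanyl in place of chloro on an aromatic carbon. For the measured compounds named here, none of the measured steps touches this position or this pair of groups; the only measured step, a 12-fold higher number from compound 1 to compound 3 (1.07 log units; beyond the scatter), concerns fluoro against iodo elsewhere on the shared core. No evidence therefore points in either direction for the chloro to sulfanyl exchange.

Lacking a measured precedent, the estimate for compound 4 rests on compound 3 alone and is broad. Compound 4 is expected to give about 120000 nM in this assay, within 25000 nM to 500000 nM. The expected step of a 1.6-fold higher number from compound 3 to compound 4 (0.20 log units; within the scatter) is a modest weakening, with real uncertainty about whether a number or only a limit will be obtained.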

Compound 4, half-maximal inhibitory concentration: > 500000 nM
Compound 4 was reported as a limit (the forecaster's own chance of this, stated with the estimate: 25%); at least 4.1-fold (0.61 log units) between middle value and limit.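

For the compounds shown here, until now the only measured step concerned fluoro against iodo, so nothing showed whether the aromatic carbon carrying chloro matters in this assay. The exchange of chloro for sulfanyl gives an at least 6.5-fold higher number from compound 3 to compound 4 (0.81 log units; beyond the scatter), which shows that inhibition on this core is sensitive to the group at this position and that this particular change weakens it. Compound 4 gives a limit rather than a number, and it is now the second such entry: the limit of > 500000 nM in this assay, at which 2 of the 4 values shown sit.

Only one replacement for chloro is shown here, so it remains open whether the loss belongs to sulfanyl itself or would follow other groups at this position, such as bromo or methoxy on the same core. From the compounds shown here alone, it is also open why sulfanyl has this effect, and whether the exchange would cost as much on the core of compound 1, which carries iodo in place of fluoro.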